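The compounds below may be only part of what the source reports. "The series", "measured", "known", "first", "only" and "open" are said of these compounds alone.

Working notes on the series. The core shared by the compounds is that of compound 2 `C=C(Br)C(=O)Nc1ccc(/C=C2\SC(=O)N(Cc3cccc(Cl)c3)C2=O)cc1`, which carries a 3-chlorobenzyl group on the amide-type nitrogen in the ring and an anilide arm on the exocyclic side. Among the compounds with values here, in a functional assay on HeLa cells (Homo sapiens) for cytotoxicity, read by cell counting, with a stated time of 4 days (a lower number here means a stronger inhibitor, a higher number a weaker inhibitor), compound 2 gives 8900 nM, the lowest of the three numbers measured so far. Compound 3 `Nc1ccc(/C=C2\SC(=O)N(Cc3cccc(Cl)c3)C2=O)cc1` gives 24000 nM, and compound 1 `CC(C)(C)c1ccc(CN2C(=O)S/C(=C\c3ccc(N)cc3)C2=O)cc1` gives 53000 nM. Within the data shown here, the only step measured between compounds differing in one place, a 2.7-fold higher number from compound 2 to compound 3 (0.43 log units; beyond the scatter), concerns the anilide arm and not the benzyl group. Compound 1 and compound 3 differ only in the group on the benzyl ring, and their two values show that this part of the molecule does move the number.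

Compound 4 `C=C(Br)C(=O)Nc1ccc(/C=C2\SC(=O)N(C)C2=O)cc1` is still to be measured. It differs from compound 2 by hydrogen in place of 3-chlorophenyl on a saturated chain carbon bound to an amide-type nitrogen in a ring. Among the measured compounds shown here, no measured step removes an aromatic ring at this place, so the expectation rests on the gap between compound 1 and compound 3 alone, and a higher number is expected, of uncertain size. Compound 4 is expected to give about 25000 nM, with a range from 8000 nM to 80000 nM. The step this estimate implies is a 2.8-fold higher number from compound 2 to compound 4 (0.45 log units; beyond the scatter).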

Compound 4, half-maximal inhibitory concentration: 870 nM
Estimate against measurement, compound 4: 29-fold (1.46 log units) above; the measured number lies below the stated range.
By their numbers in this assay, from the lowest: compound 4; then compound 2; then compound 3; then compound 1.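

In this assay the change from 3-chlorobenzyl to methyl gives a 10-fold lower number from compound 2 to compound 4 (1.01 log units; beyond the scatter) and shows that, with the (1-bromoethenyl)carbonyl arm present, the 3-chlorophenyl ring is not required at this place for the cytotoxic effect, and that its removal goes with the lower number. This step is also larger than a 2.7-fold higher number from compound 2 to compound 3 (0.43 log units; beyond the scatter) on the anilide arm, so of the two steps measured between compounds differing in one place, the change at this place moves the number more. Nothing available here accounts for the drop.

The compounds shown leave open whether the same change would lower the number with the free amine arm of compound 3. Also open, from the compounds shown here alone, is how an ethyl group, a longer chain or a hydrogen on this ring nitrogen would compare with compound 4.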